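Para halogen swap on the benzylamide of the series

A few compounds are considered here, and "the series" means these few. Any claim that something is new, unique, unknown or untested is made for them only; others in the source may bear on it.

Compound 1 `CCC(C(=O)NCc1ccccc1Cl)N1C(=O)CCC1=O` and compound 2 `CCC(C(=O)NCc1ccc(Cl)cc1)N1C(=O)CCC1=O` share one core and differ only in the chlorophenyl group. In a functional assay on the whole organism (strain Albino Swiss CD1) with Mus musculus as the target (a lower number here means that less compound is needed, a higher number that more compound is needed for the effect), compound 1 gives 76.4 mg/kg and compound 2 gives 50.8 mg/kg; the step of a 1.5-fold lower number from compound 1 to compound 2 (0.18 log units; within the scatter) is the only one measured, and it leaves compound 2 with the lowest of two numbers, its nearest neighbour compound 1 within the scatter. Compound 3 `CCC(C(=O)NCc1ccc(F)cc1)N1C(=O)CCC1=O` carries fluoro in place of chloro on an aromatic carbon. Within the data shown here, no measured step exchanges one halogen for another, and the single step measured stayed within the scatter, so no change beyond the scatter is expected for compound 3. The expected step of a 1.2-fold higher number from compound 2 to compound 3 (0.07 log units; within the scatter) is estimated to stay within the scatter. Compound 3 is expected to give 60 mg/kg in this assay, with a range from 30 mg/kg to 120 mg/kg.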

Compound 3, dose for half-maximal effect: 83.4 mg/kg
Beside the measured number, compound 3's estimate is 1.4-fold (0.14 log units) below it; the range from low to high includes it.
By their numbers in this assay, from the lowest: compounds 2, 1 and 3 (each within the scatter of the next).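

Chloro to fluoro on the aromatic carbon gives a 1.6-fold higher number from compound 2 to compound 3 (0.22 log units; within the scatter) in this assay, so this halogen exchange stays within the scatter. Changing both halogen and ring place together gives a 1.1-fold higher number from compound 1 to compound 3 (0.04 log units; within the scatter), also within the scatter, so neither change separates the three compounds in this assay. Nothing available bears on the reason for this result. Going by these compounds, whether bromo, methoxy or trifluoromethyl on the same carbon would give a step beyond the scatter stays open. So does the outcome of an unsubstituted phenyl ring on the shared core.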